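A few compounds are considered here, and "the series" means these few. Any claim that something is new, unique, unknown or untested is made for them only; others in the source may bear on it.

Compound 1 `CCOC(=O)c1sc2cc(Oc3ccnc(C(=O)NC)c3)ccc2c1C`: 50900 nM
Compound 2 `CCCOC(=O)c1sc2cc(Oc3ccnc(C(=O)NC)c3)ccc2c1C`: 37400 nM
Compound 3 `CNC(=O)c1cc(Oc2ccc3c(C)c(C(=O)O)sc3c2)ccn1`: > 100000 nM (a limit of the assay, not a number)

In an ADME assay on H1-HeLa cells (Homo sapiens) for cytotoxicity, read by MTT assay, with a stated time of 3 days (on this read-out higher numbers stand for lower toxicity in this test and lower numbers for higher toxicity in this test), compound 1 gives 50900 nM, and compound 2 lies within the scatter of it, a 1.4-fold lower number from compound 1 to compound 2 (0.13 log units; within the scatter). Compound 3 is reported only as a limit, > 100000 nM.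

Compound 4 `CCOC(=O)c1sc2cc(Oc3ccnc(C(=O)NC)c3)ccc2c1N` carries amino in place of methyl on an aromatic carbon. Among the measured compounds shown here, no measured step touches this carbon. All of them alter the ethoxycarbonyl group, so they bear on the change only loosely: a 1.4-fold lower number from compound 1 to compound 2 (0.13 log units; within the scatter), an at least 1.9-fold higher number from compound 1 to compound 3 (0.29 log units; that floor lies within the scatter) and an at least 2.6-fold higher number from compound 2 to compound 3 (0.42 log units; beyond the scatter). With so little to go on, no step beyond the scatter is expected, and the estimated step is a 1.3-fold lower number from compound 1 to compound 4 (0.10 log units; within the scatter). Compound 4 is expected near 40000 nM, with an estimated range of 12000 nM to 100000 nM.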

Compound 4, half-maximal cytotoxic concentration: 110 nM
Estimate against measurement, compound 4: 360-fold (2.56 log units) above; measured number outside the range, below it.
By their numbers in this assay, from the lowest: compound 4; then compounds 2 and 1 (each within the scatter of the next). At a limit, above all of these: compound 3.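

In this assay, the aromatic carbon next to the ring atom that bears the ethoxycarbonyl group turns out to matter greatly, which the earlier changes to that ester group could not show: the step is a 460-fold lower number from compound 1 to compound 4 (2.67 log units; beyond the scatter). The swap is small, one heavy atom for one, with amino bringing a hydrogen-bond donor and acceptor that methyl lacks. Nothing measured here explains a step of this size. Open still is whether a hydroxyl or dimethylamino group on this carbon would act like amino, and whether amino has the same effect when a carboxylic acid replaces the ethoxycarbonyl group.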